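Notes on ester side chains at the amide nitrogen

The compounds below may be only part of what the source reports. "The series", "measured", "known", "first", "only" and "open" are said of these compounds alone.

Measured so far in a functional assay on BGC-823 cells (Homo sapiens) for cytotoxicity, read by MTT assay, with a stated time of 24 h; a lower number here means a stronger inhibitor, a higher number a weaker inhibitor:
- compound 1 `CC[C@H](C)[C@@H](NC(=O)Cn1cc(C2=C(c3c[nH]c4ccccc34)C(=O)N(C)C2=O)c2ccccc21)C(=O)OC`: > 100000 nM
- compound 2 `COC(=O)[C@H](NC(=O)Cn1cc(C2=C(c3c[nH]c4ccccc34)C(=O)N(C)C2=O)c2ccccc21)[C@@H](C)O`: 23300 nM
- compound 3 `COC(=O)CCNC(=O)Cn1cc(C2=C(c3c[nH]c4ccccc34)C(=O)N(C)C2=O)c2ccccc21`: 44900 nM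

The value of compound 1 is a limit of this assay, not a number (the limit of > 100000 nM in this assay, at which 1 of the 3 values shown sits). Among the two numbers, compound 3 gives the higher one, but the step of a 1.9-fold higher number from compound 2 to compound 3 (0.28 log units; within the scatter) falls within the scatter. The step of an at least 2.2-fold lower number from compound 1 to compound 3 (0.34 log units; beyond the scatter) is at least modest, and the step of an at least 4.2-fold lower number from compound 1 to compound 2 (0.63 log units; beyond the scatter) is of similar size.

The next compound, compound 4 `COC(=O)CC[C@@H](NC(=O)Cn1cc(C2=C(c3c[nH]c4ccccc34)C(=O)N(C)C2=O)c2ccccc21)C(=O)OC`, changes the side chain once more: 1,3-bis(methoxycarbonyl)propyl in place of 2-(methoxycarbonyl)ethyl on an amide-type nitrogen. Both measured steps onto or away from compound 3 concern the same amide nitrogen; one was beyond the scatter, the other within it. The entering group again carries a methoxycarbonyl on the carbon bound to the nitrogen, as in compound 2, which gave 23300 nM, and as in compound 1. The value of compound 1 is only a limit. On that basis no step beyond the scatter is expected, with some risk of a weaker number, so compound 4 is estimated at 45000 nM in this assay, within 15000 nM to 130000 nM. This expectation corresponds to a step of a 1.0-fold higher number from compound 3 to compound 4 (0.00 log units; within the scatter).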

Compound 4, half-maximal inhibitory concentration: 25000 nM
Estimate against measurement, compound 4: 1.8-fold (0.26 log units) above; the measured number falls inside the stated range.
By their numbers in this assay, from the lowest: compounds 2, 4 and 3 (each within the scatter of the next). At a limit, above all of these: compound 1.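

In this assay, the 1,3-bis(methoxycarbonyl)propyl side chain on the amide-type nitrogen adds a second methoxycarbonyl and a defined stereocentre to the 2-(methoxycarbonyl)ethyl chain, yet the result is a 1.8-fold lower number from compound 3 to compound 4 (0.25 log units; within the scatter), so this enlargement leaves the number within the scatter. On the saturated chain carbon bound to the amide-type nitrogen and a carbonyl carbon, 2-(methoxycarbonyl)ethyl in place of 1-hydroxyethyl gives a 1.1-fold higher number from compound 2 to compound 4 (0.03 log units; within the scatter), while 2-(methoxycarbonyl)ethyl in place of sec-butyl gives an at least 4.0-fold lower number from compound 1 to compound 4 (0.60 log units; beyond the scatter), which makes a second substituent on that carbon separate from sec-butyl by a step beyond the scatter. Among the compounds carrying a substituent there, only compound 1 stands apart, and its value is a limit of the assay, not a number: the limit of > 100000 nM in this assay, at which 1 of the 4 values shown sits.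

Going by these compounds, whether a free carboxylic acid in place of either methyl ester, or a primary amine at the end of the side chain, would move the number beyond the scatter remains open. Also open, on these data alone, is whether a longer chain carrying the methoxycarbonyl, or the opposite configuration at the stereocentre of compound 4, would change the reading.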